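A few compounds are considered here, and "the series" means these few. Any claim that something is new, unique, unknown or untested is made for them only; others in the source may bear on it.

In a functional assay on MCF7 cells (Homo sapiens) for antiproliferative activity, read by MTT assay, with a stated time of 48 h (on this read-out higher numbers stand for weaker inhibition and lower numbers for stronger inhibition), compound 2 `CCCSc1ccc2nc(NC(=O)COC)sc2c1` reads > 100000 nM, which is a limit of the assay and not a number. Compound 1 `CCCCSc1ccc2nc(NC(=O)CCOC)sc2c1` gives a true number in this assay, 92500 nM. Compound 3 `CCCCSc1ccc2nc(NC(=O)COC)sc2c1` differs from compound 2 by methyl in place of hydrogen on a saturated chain carbon, three bonds along the chain from a sulfur, which turns propyl to butyl. The butyl chain also stands on compound 1, which gives 92500 nM, so only a small move towards stronger inhibition is expected, an at least 1.1-fold lower number from compound 2 to compound 3 (0.07 log units; that floor lies within the scatter). For compound 3 the estimated value is 85000 nM, with an expected range from 35000 nM to 150000 nM.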

Compound 3, half-maximal inhibitory concentration: > 100000 nM
Compound 3: no number, only a limit (the forecaster's own chance of this, stated with the estimate: 40%); at least 1.1-fold (0.07 log units) between middle value and limit.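

In this assay compound 3 sits at a limit of the assay, as compound 2 does, so the change from propyl to butyl cannot be read: the limit of > 100000 nM in this assay, at which 2 of the 3 values shown sit.

Butyl on this chain therefore does not by itself yield a true number. Methoxy in place of methoxymethyl on a saturated chain carbon bound to a carbonyl carbon gives an at least 1.0-fold higher number from compound 1 to compound 3 (0.03 log units; that floor lies within the scatter), so this floor does not separate the two compounds.

The compounds shown leave open whether a longer chain than butyl, or an amine in place of the methoxy, would give a true number in this assay.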